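This account rests on a few compounds, and the source may have more. Where it says the series, first, only, none or still open, it means among the compounds named here.

Compounds measured in a functional assay on L02 cells (Homo sapiens) for inhibition, read by Griess assay, with stated times of 1 h and 24 h; a higher number here means a weaker inhibitor, a lower number a stronger inhibitor:
- compound 1 `COc1cc(/C=C/c2nc(N(C)C)c3sccc3n2)cc(OC)c1OC`: > 1000000 nM
- compound 2 `COc1cc(/C=C/c2nc(N3CCN(C)CC3)c3sccc3n2)cc(OC)c1OC`: > 1000000 nM

Both values are limits, not numbers. Compound 2 thus stands at the limit of > 1000000 nM in this assay, at which 2 of the 2 values shown sit. Compound 3 `CCN1CCN(c2nc(/C=C/c3cc(OC)c(OC)c(OC)c3)nc3ccsc23)CC1` differs from compound 2 by methyl in place of hydrogen on a saturated chain carbon bound to an amine nitrogen in a ring, which makes 4-methylpiperazin-1-yl into 4-ethylpiperazin-1-yl. For the measured compounds named here, the only measured step bearing on this is a step that the two limits leave unreadable from compound 1 to compound 2, and it gives no size to carry over. No shift beyond the scatter is therefore expected in this assay, and the expected change is a number no higher from compound 2 to compound 3 (the limit leaves the size open). Compound 3 is estimated at 1000000 nM, within an expected range of 200000 nM to 3000000 nM.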

Compound 3, half-maximal inhibitory concentration: > 1000000 nM
Compound 3 ended at the assay's limit; the forecaster's own chance of this, stated with the estimate: 85%; the middle value sits exactly at the limit.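

In this assay no step can be read among compound 1, compound 2 and compound 3, since each stands at a limit: the limit of > 1000000 nM in this assay, at which 3 of the 3 values shown sit.
The compounds shown leave open whether changing the group on the shared core alters inhibition at all.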